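The source may report more compounds than this note shows. Statements on the series, on what has been measured and on what is new or still open speak of the compounds shown alone.

Compound 1, `NC(=O)c1c(NC(=O)c2ccccc2Cl)sc2c1CCN(Cc1ccc(Cl)cc1Cl)C2`: 8010 nM in a functional assay on HL-60 cells (Homo sapiens) for antiproliferative activity, with a stated time of 24 h; a lower number here means a stronger inhibitor, a higher number a weaker inhibitor. Compound 2, `NC(=O)c1c(NC(=O)c2cccc([N+](=O)[O-])c2)sc2c1CCN(Cc1c(Cl)cccc1Cl)C2`: 18400 nM in this assay.

Of the two measured compounds, compound 2 gives the higher number in this assay, and the gap to compound 1 lies beyond the usual scatter. Compound 3, `NC(=O)c1c(NC(=O)c2cccc([N+](=O)[O-])c2)sc2c1CCN(Cc1ccc(Cl)cc1Cl)C2`, keeps the nitro-bearing amide of compound 2 and changes only the benzyl group: 2,4-dichlorophenyl in place of 2,6-dichlorophenyl on a saturated chain carbon bound to an amine nitrogen in a ring. Among the measured compounds shown here, no measured pair shows this change on its own, so its size is an open question; compound 1 carries the same 2,4-dichlorobenzyl group. Compound 3 is expected to give a somewhat lower number than compound 2, with the step of a 1.5-fold lower number from compound 2 to compound 3 (0.19 log units; within the scatter) judged small and possibly within scatter. The estimate for compound 3 is 12000 nM, ranging from 4000 nM to 35000 nM.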

Compound 3, half-maximal inhibitory concentration: 19800 nM
Compound 3: the middle estimate sits 1.7-fold (0.22 log units) below what was measured; low and high end bracket the measured number.
By their numbers in this assay, from the lowest: compound 1; then compounds 2 and 3 (each within the scatter of the next).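

In this assay, 2,4-dichlorophenyl in place of 2,6-dichlorophenyl on a saturated chain carbon bound to an amine nitrogen in a ring gives a 1.1-fold higher number from compound 2 to compound 3 (0.03 log units; within the scatter) and so does not separate the two compounds. Among the compounds shown here, with the 2,4-dichlorobenzyl group held constant, 3-nitrophenyl in place of 2-chlorophenyl on a carbonyl carbon gives a 2.5-fold higher number from compound 1 to compound 3 (0.39 log units; beyond the scatter) and is the only single-place step here beyond the scatter. Nothing available explains either step.

On these data alone, whether the benzyl change would behave alike in compounds carrying 2-chlorophenyl on the carbonyl carbon stays open. So does the effect of an amine or a methoxy group in place of the nitro group.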